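Thiophen-2-yl in place of 4-chlorophenyl on the triple bond

The source may report more compounds than this note shows. Statements on the series, on what has been measured and on what is new or still open speak of the compounds shown alone.

Compound 3 `O=C1c2ccc(C#Cc3ccc(Cl)cc3)nc2CCN1C1CCCC1` gives 979 nM in a functional assay on HEK293 cells for positive allosteric modulation of metabotropic glutamate receptor 5 (Homo sapiens), read by FLIPR and calcium flux (on this read-out lower numbers stand for an effect already at smaller amounts and higher numbers for an effect only at larger amounts of compound), the highest number of the three measured; compound 2 `O=C1c2ccc(C#Cc3ccccc3Cl)nc2CCN1C1CCCC1` gives 393 nM and compound 1 `O=C1c2ccc(C#Cc3ccccc3)nc2CCN1C1CCCC1` gives 5.9 nM. Compound 4 `O=C1c2ccc(C#Cc3cccs3)nc2CCN1C1CCCC1` differs from compound 3 in one place: thiophen-2-yl in place of 4-chlorophenyl on a triple-bonded carbon. Among the measured compounds shown here, two measured steps bear on this: a 170-fold higher number from compound 1 to compound 3 (2.22 log units; beyond the scatter) and a 2.5-fold higher number from compound 2 to compound 3 (0.40 log units; beyond the scatter). Both show that a chlorine on the aromatic ring raises the number sharply, and compound 4 carries no chlorine but a bare five-membered aromatic ring. A large fall in the number, a 65-fold lower number from compound 3 to compound 4 (1.81 log units; beyond the scatter), is expected for compound 4, because compound 1 with its unsubstituted ring gives 5.9 nM. For compound 4 the estimate is 15 nM, expected between 4 nM and 60 nM.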

Compound 4, half-maximal effective concentration: 12 nM
The estimate for compound 4 lay 1.3-fold (0.10 log units) above the measured number; the measured number falls inside the stated range.
By their numbers in this assay, from the lowest: compound 1; then compound 4; then compound 2; then compound 3.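

Thiophen-2-yl on the triple-bonded carbon brings the number back down, with an 82-fold lower number from compound 3 to compound 4 (1.91 log units; beyond the scatter) and a 33-fold lower number from compound 2 to compound 4 (1.52 log units; beyond the scatter) showing that this position also takes a five-membered aromatic ring holding sulfur, not only phenyl. The change from the unsubstituted ring is modest but beyond the scatter, with a 2.0-fold higher number from compound 1 to compound 4 (0.31 log units; beyond the scatter) as the step. Nothing measured here gives a reason for these steps.

Open, on these data alone, is whether a furan or pyridine ring would match thiophen-2-yl. Also open, as far as these compounds go, is whether a chloro or methyl group on the thiophene would raise the number as chloro does on the phenyl ring.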